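The compounds below may be only part of what the source reports. "The series", "measured", "known", "first", "only" and "open" are said of these compounds alone.

In a functional assay on the whole organism (strain Kunming) with Mus musculus as the target, with a stated time of 0.5 h, at a dose of 300 mg/kg by the intraperitoneal route (a lower number here means a stronger effect, a higher number a weaker effect of the compound at the dose given), compound 3 `COc1cc(OC)c(OC)cc1/C=C/COC(=O)/C=C/c1ccccc1Cl` gives 25%, level with compound 1 `COc1cc(OC)c(OC)cc1/C=C/COC(=O)/C=C/c1ccc(Br)cc1` at 25%, and these two together are the lowest of the three numbers; compound 2 `COc1cc(OC)c(OC)cc1/C=C/COC(=O)/C=C/c1ccccc1C(F)(F)F` gives 50%. The step of no change at the digits printed from compound 1 to compound 3 (within the scatter) lies within the scatter, whereas a number 25 percentage points lower from compound 2 to compound 3 (beyond the scatter) and a number 25 percentage points higher from compound 1 to compound 2 (beyond the scatter) lie beyond it. Compound 4 `COc1cc(OC)c(OC)cc1/C=C/COC(=O)/C=C/c1ccc(F)cc1` differs from compound 3 by 4-fluorophenyl in place of 2-chlorophenyl on a double-bonded chain carbon bound to a double-bonded chain carbon. Within the data shown here, no measured step exchanges chlorine for fluorine on this ring, and the only guide is the step of no change at the digits printed from compound 1 to compound 3 (within the scatter), where a 4-bromophenyl and a 2-chlorophenyl gave the same number. On that basis the step of no change at the digits printed from compound 3 to compound 4 (within the scatter) is expected to stay within the scatter. Compound 4 is estimated at 25%, with a range from 5% to 50%.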

Compound 4, a percentage reported as activity, at one dose (the size of the read-out at that dose, not a potency): 0%
For compound 4 the middle estimate is 25 percentage points above the measured one; the measured number lies below the stated range.
By their numbers in this assay, from the lowest: compound 4; then compounds 1 and 3 (each within the scatter of the next); then compound 2.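

In this assay, among these compounds, the aryl group on this double-bonded chain carbon separates further than the earlier compounds showed: 4-bromophenyl and 2-chlorophenyl had been level, but 4-fluorophenyl breaks from both, with a number 25 percentage points lower from compound 1 to compound 4 (beyond the scatter) for fluoro in place of bromo and a number 25 percentage points lower from compound 3 to compound 4 (beyond the scatter) for the exchange with 2-chlorophenyl. The widest step now reaches a number 50 percentage points lower from compound 2 to compound 4 (beyond the scatter), and compound 4 has the strongest effect of the set. No measurement given here explains this result. The compounds leave open whether the gain belongs to fluoro itself or would also appear with an unsubstituted phenyl or a 4-methoxyphenyl. They also leave open how an amine on this ring would behave.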